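Oxygen-bearing versus fluorinated substituents on the aniline ring

This account rests on a few compounds, and the source may have more. Where it says the series, first, only, none or still open, it means among the compounds named here.

Measured so far:
compound 1 `CCCCOc1cccc(Nc2nc3nonc3nc2O)c1`, 2300 nM
compound 2 `Oc1nc2nonc2nc1Nc1cccc(F)c1`, 31200 nM
compound 3 `Oc1nc2nonc2nc1Nc1cccc(C(F)(F)F)c1`, 13300 nM

In an assay on mitochondria from L6 cells (Rattus norvegicus) for activation, with a stated time of 90 min (a higher number here means that more compound is needed for the effect, a lower number that less compound is needed), compound 3 stands second highest of the three numbers. Its nearest neighbour is compound 2: a 2.3-fold lower number from compound 2 to compound 3 (0.37 log units; beyond the scatter). The furthest is compound 1: a 5.8-fold higher number from compound 1 to compound 3 (0.76 log units; beyond the scatter), so the butoxy compound needs the least material of the set.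

Compound 4 `Oc1nc2nonc2nc1Nc1cccc(OC(F)(F)F)c1` differs from compound 3 in one place: trifluoromethoxy in place of trifluoromethyl on an aromatic carbon. Within the data shown here, two measured steps bear on this. The step of a 2.3-fold lower number from compound 2 to compound 3 (0.37 log units; beyond the scatter) shows that exchanging one fluorinated group for another moves the number only modestly. The step of a 5.8-fold higher number from compound 1 to compound 3 (0.76 log units; beyond the scatter) shows that the butoxy group, which carries an oxygen on the ring, gave a clearly lower number than trifluoromethyl. Trifluoromethoxy sits between these cases, so a modest lowering is expected in this assay rather than a large one.

Compound 4 is therefore estimated at 6500 nM (range 2500 nM to 16000 nM), an expected step of a 2.0-fold lower number from compound 3 to compound 4 (0.31 log units; beyond the scatter).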

Compound 4, half-maximal effective concentration: 5100 nM
Compound 4: middle estimate off by 1.3-fold (0.11 log units), on the high side; low and high end bracket the measured number.
By their numbers in this assay, from the lowest: compound 1; then compound 4; then compound 3; then compound 2.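

In this assay, among these compounds, trifluoromethoxy in place of trifluoromethyl on this aromatic carbon, meta to a large group, gives a 2.6-fold lower number from compound 3 to compound 4 (0.42 log units; beyond the scatter) and is the first sign that a fluorinated group carrying an oxygen on the ring can lower the number. Against the smallest substituent in the set, trifluoromethoxy in place of fluoro gives a 6.1-fold lower number from compound 2 to compound 4 (0.79 log units; beyond the scatter), so both oxygen-bearing compounds lie below both compounds without that oxygen, with no exception among these four. The oxygen alone does not set the number, since trifluoromethyl in place of butyl on that oxygen still gives a 2.2-fold higher number from compound 1 to compound 4 (0.35 log units; beyond the scatter).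

No available evidence accounts for this order. Open, from the compounds shown here alone, is how an amine, a methoxy group or a longer alkoxy chain would behave on this aromatic carbon.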